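Alkoxy shortening in the pyridinone amide series

A few compounds are considered here, and "the series" means these few. Any claim that something is new, unique, unknown or untested is made for them only; others in the source may bear on it.

Measured so far:
compound 1 `Cc1cc(C)c(CNC(=O)c2cccc(OC(C)C)c2Cl)c(=O)[nH]1`: 2
compound 2 `Cc1cc(C)c(CN2CCc3c(Cl)cc(-c4c(C)noc4C)c(Cl)c3C2=O)c(=O)[nH]1`: 3.1
compound 3 `Cc1cc(C)c(CNC(=O)c2cccc(OC(C)C)c2C)c(=O)[nH]1`: 2.1

In a physicochemical assay for lipophilicity, at pH 7.4 (on this read-out higher numbers stand for higher lipophilicity and lower numbers for lower lipophilicity), compound 3 stands second highest of the three numbers, with compound 1 nearest, lower by a gap within the scatter, and compound 2 furthest, higher by a gap beyond the scatter. Within the data shown here, the only measured single step is a number 0.10 log units higher from compound 1 to compound 3 (within the scatter), which concerns the aromatic substituent rather than the ether.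

Compound 4 `COc1cccc(C(=O)NCc2c(C)cc(C)[nH]c2=O)c1C` differs from compound 3 by methyl in place of isopropyl on an oxygen on an aromatic ring. Among the measured compounds shown here, no measured pair in this set changes the alkoxy group, so the size of this step cannot be read from a measured step. For an isopropyl giving way to a methyl, a fall in this assay beyond the scatter is nevertheless expected, estimated at a number 0.80 log units lower from compound 3 to compound 4 (beyond the scatter). The expected value for compound 4 is 1.3, with a range from 0.9 to 1.7.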

Compound 4, distribution coefficient: 1.5
Estimate against measurement, compound 4: 0.20 log units below; measured number inside the range.
By their numbers in this assay, from the lowest: compound 4; then compounds 1 and 3 (each within the scatter of the next); then compound 2.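

In this assay, among these compounds, isopropoxy to methoxy gives the first measured step at this oxygen, a number 0.60 log units lower from compound 3 to compound 4 (beyond the scatter), so the number responds to a change on the ether, whereas the one earlier step, on the aromatic carbon, stayed within the scatter. The step comes from a single pair, with methyl on the aromatic carbon. No available evidence bears on the reason for it.

Going by these compounds, whether the same change holds with chloro on that carbon remains open. So does the reading for an ethoxy group, a longer alkoxy chain or an ether carrying an amine.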